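The source may hold more compounds than are shown below. What is called first, only, known or untested is meant among the compounds shown, and "the series" means these compounds.

Notes on the series in a functional assay on HepG2 cells (Homo sapiens) for antiproliferative activity, read by MTT assay, with a stated time of 48 h (on this read-out higher numbers stand for weaker inhibition and lower numbers for stronger inhibition), follow. Compound 1 (`C#Cc1cccc(Nc2ncnc3cc(NC(=O)/C=C/c4ccccc4)sc23)c1`) gives 15400 nM and stands within the scatter of compound 3 (`O=C(/C=C/c1ccccc1)Nc1cc2c(Nc3ccc(F)c(Cl)c3)ncnc2s1`) at 22800 nM and of compound 2 (`COc1ccc(/C=C/C(=O)Nc2cc3c(Nc4ccc(Cl)c(Cl)c4)ncnc3s2)cc1`) at 30600 nM as well. Compound 4 (`O=C(/C=C/c1ccccc1)Nc1cc2ncnc(Nc3cc(Cl)cc(Cl)c3)c2s1`) has 3,5-dichlorophenyl in place of 3-ethynylphenyl on a nitrogen on an aromatic ring. Going by the values given here, no step between measured compounds differing in one place is available. Compound 2 at 30600 nM and compound 3 at 22800 nM carry chlorine on their phenyl groups and lie within the scatter of compound 1 at 15400 nM so no step beyond the scatter is expected in this assay. The step is estimated as a 1.4-fold higher number from compound 1 to compound 4 (0.13 log units; within the scatter) on these numbers. Compound 4 is expected at 21000 nM within an estimated range of 8000 nM to 50000 nM for now.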

Compound 4, half-maximal inhibitory concentration: 10700 nM
Compound 4: middle estimate off by 2.0-fold (0.29 log units), on the high side; low and high end bracket the measured number.
By their numbers in this assay, from the lowest: compounds 4, 1, 3 and 2 (each within the scatter of the next, the first and the last beyond it).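

In this assay, replacing 3-ethynylphenyl with 3,5-dichlorophenyl on a nitrogen on an aromatic ring gives a 1.4-fold lower number from compound 1 to compound 4 (0.16 log units; within the scatter), the first step read at this position on the core of compound 1. The position therefore accepts either group, with loss of the triple bond and entry of two chlorine atoms, without a step beyond the scatter. Nothing measured here offers a cause for this result. Still open, going by these compounds, is whether an amine or a carboxylic acid on this phenyl group would move the number beyond the scatter.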